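Aryloxy sulfamoyl carbamates on the diisopropylphenyl core

The compounds below may be only part of what the source reports. "The series", "measured", "known", "first", "only" and "open" are said of these compounds alone.

Measured compounds:
compound 1, `CC(C)c1cccc(C(C)C)c1OC(=O)NS(=O)(=O)N1CCc2ccccc21`, gives 43000 nM in an assay on liver for inhibition of sterol O-acyltransferase 1 (Rattus norvegicus), using microsomes; a lower number here means a stronger inhibitor, a higher number a weaker inhibitor
compound 2, `CC(C)c1cccc(C(C)C)c1OC(=O)NS(=O)(=O)Oc1ccc(F)cc1F`, gives > 50000 nM in this assay

Compound 2 stands at the limit of this assay, so its reading of > 50000 nM is a limit and not a number; see (the limit of > 50000 nM in this assay, at which 1 of the 2 values shown sits). Going by the values given here, the one measured step, an at least 1.1-fold higher number from compound 1 to compound 2 (0.06 log units; that floor lies within the scatter), runs from compound 1 into that limit and touches the group on the sulfonyl sulfur, not the aryl ring on the oxygen.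

Compound 3, `Cc1cccc(C)c1OS(=O)(=O)NC(=O)Oc1c(C(C)C)cccc1C(C)C`, differs from compound 2 by 2,6-dimethylphenyl in place of 2,4-difluorophenyl on an oxygen. Among the compounds with values here, no measured step bears on an aryl-to-aryl exchange at this oxygen, so the measured steps give no direction for it. With compound 2 already at the limit, compound 3 is expected to stay near that limit, a step of a number no higher from compound 2 to compound 3 (the limit leaves the size open) meaning no change beyond the scatter. The estimate for compound 3 in this assay is 50000 nM, within 15000 nM to 200000 nM.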

Compound 3, half-maximal inhibitory concentration: > 50000 nM
Compound 3: no number, only a limit (the forecaster's own chance of this, stated with the estimate: 55%); the middle value lies on the limit itself.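

In this assay, the step from the 2,4-difluorophenyl to the 2,6-dimethylphenyl group on this oxygen cannot be read, because compound 2 and compound 3 both sit at a limit: the limit of > 50000 nM in this assay, at which 2 of the 3 values shown sit.

Replacing the group of compound 1 on the sulfonyl sulfur with 2,6-dimethylphenoxy gives an at least 1.1-fold higher number from compound 1 to compound 3 (0.06 log units; that floor lies within the scatter), so this second aryloxy group is not separated from compound 1 in this assay. Both aryloxy compounds shown now end at a limit, so neither fluorine nor methyl on the aryl ring yields a number here.

Going by these compounds, whether any group on this oxygen gives a number stays open, for instance an aryl ring carrying a carboxylic acid or an amine, or a butyl chain in place of the aryl ring. Also open, on these data alone, is how the reading of compound 1 moves with a piperidine on the sulfonyl sulfur.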